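A few compounds are considered here, and "the series" means these few. Any claim that something is new, unique, unknown or untested is made for them only; others in the source may bear on it.

Compound 1 (`Cc1cc(S(=O)(=O)NC(=O)c2ccc(N3CCN(Cc4ccccc4-c4ccc(Cl)cc4)CC3)cc2)ccc1N[C@H](CCN(C)C)CSc1ccccc1`) and compound 2 (`CN(C)CC[C@H](CSc1ccccc1)Nc1ccc(S(=O)(=O)NC(=O)c2ccc(N3CCN(Cc4ccccc4-c4ccc(Cl)cc4)CC3)cc2)cc1S(C)(=O)=O`) share the core of compound 3 (`CN(C)CC[C@H](CSc1ccccc1)Nc1ccc(S(=O)(=O)NC(=O)c2ccc(N3CCN(Cc4ccccc4-c4ccc(Cl)cc4)CC3)cc2)cc1S(=O)(=O)C(F)(F)F`), but they add little to what is known about exposure. In an ADME assay on the whole organism (plasma, strain Sprague-Dawley) for pharmacokinetics, with Rattus norvegicus as the target, at a dose of 5 mg/kg by the oral route (on this read-out lower numbers stand for lower exposure and higher numbers for higher exposure at the dose given), compound 1 is reported as "not determined" (no result reported). Compound 2 is likewise reported as "not determined" (no result reported). Going by the values given here, compound 3 gives 747 ng.h/mL, so it stands alone as the single number, with nothing measured to rank it against.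

The next compound to be tested is compound 4 (`CN(C)CC[C@H](CSc1ccccc1)Nc1ccc(S(=O)(=O)NC(=O)c2ccc(N3CCN(Cc4ccccc4-c4ccc(Cl)cc4)CC3)cc2)cc1C#N`). It keeps the same core and carries cyano in place of (trifluoromethyl)sulfonyl on an aromatic carbon.

Among the compounds with values here, no two measured compounds differ in one place, so the series offers no measured step that could show how much such a change moves this assay, or in which direction. With compound 3 at 747 ng.h/mL as the sole anchor, no direction can be favoured. The estimated 1.1-fold lower number from compound 3 to compound 4 (0.03 log units; within the scatter) is therefore expected to stay within the usual scatter, although a larger move in either direction cannot be excluded. For compound 4 the expected exposure is 700 ng.h/mL, with an estimated range from 150 ng.h/mL to 3000 ng.h/mL.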

Compound 4, area under the concentration-time curve: 1740 ng.h/mL
Beside the measured number, compound 4's estimate is 2.5-fold (0.40 log units) below it; measured number inside the range.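

Going by these compounds alone, on an aromatic carbon that is ortho to a large group and meta to a large group, the substituent can shift this assay beyond the usual scatter: cyano in place of (trifluoromethyl)sulfonyl gives a 2.3-fold higher number from compound 3 to compound 4 (0.37 log units; beyond the scatter) as the first measured step. Within the data shown here, this modest step gives the change a direction that the single earlier number could not provide, with the higher exposure going to compound 4, where 2 heavy atoms have entered and 7 have left. Nothing at hand accounts for this rise.

One pair cannot tell whether the gain follows from the smaller count of heavy atoms or belongs to cyano itself, and the methyl of compound 1 and the methylsulfonyl of compound 2 carry no number that could help to decide. A chlorine atom, a carboxylic acid or a primary amide on the same aromatic carbon would show how far exposure at this position can move and whether cyano stands out among such groups.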